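Swapping thiophen-2-yl for 3-bromophenyl on the arylidene arm

The source may report more compounds than this note shows. Statements on the series, on what has been measured and on what is new or still open speak of the compounds shown alone.

Compound 1 `O=C1N=C(N2CCC[C@H]2C(=O)Nc2ccc3ncnc(Nc4cccc(Cl)c4)c3c2)S/C1=C/c1ccccc1Cl`: 28100 nM
Compound 2 `O=C1N=C(N2CCC[C@H]2C(=O)Nc2ccc3ncnc(Nc4cccc(Cl)c4)c3c2)S/C1=C/c1ccc(-c2ccccc2)cc1`: 15400 nM
Compound 3 `O=C1N=C(N2CCC[C@H]2C(=O)Nc2ccc3ncnc(Nc4cccc(Cl)c4)c3c2)S/C1=C/c1cccs1`: 4120 nM

These three compounds share one core and differ only in the aromatic group on a double-bonded chain carbon bound to a double-bonded ring carbon. In a functional assay on HepG2 cells (Homo sapiens) for antiproliferative activity, read by MTT assay (a higher number here means a weaker inhibitor, a lower number a stronger inhibitor), compound 3 gives the lowest number of the three, the others standing at a 6.8-fold lower number from compound 1 to compound 3 (0.83 log units; beyond the scatter) and a 3.7-fold lower number from compound 2 to compound 3 (0.57 log units; beyond the scatter). Compound 4 `O=C1N=C(N2CCC[C@H]2C(=O)Nc2ccc3ncnc(Nc4cccc(Cl)c4)c3c2)S/C1=C/c1cccc(Br)c1` carries 3-bromophenyl in place of thiophen-2-yl on a double-bonded chain carbon bound to a double-bonded ring carbon. Both measured steps bear on this: replacing a six-membered carbon ring by thiophen-2-yl lowered the number each time, and compound 4 reverses that direction, with the 2-chlorophenyl of compound 1 the closer precedent. A rise is therefore expected, a 3.6-fold higher number from compound 3 to compound 4 (0.56 log units; beyond the scatter). Compound 4 is estimated at 15000 nM, within 4500 nM to 45000 nM.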

Compound 4, half-maximal inhibitory concentration: 21300 nM
Beside the measured number, compound 4's estimate is 1.4-fold (0.15 log units) below it; the range from low to high includes it.
By their numbers in this assay, from the lowest: compound 3; then compounds 2, 4 and 1 (each within the scatter of the next).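

In this assay, the gap in favour of thiophen-2-yl now holds against a third six-membered carbon ring, with a 5.2-fold higher number from compound 3 to compound 4 (0.71 log units; beyond the scatter). The three six-membered carbon rings do not separate from one another: a 1.4-fold higher number from compound 2 to compound 4 (0.14 log units; within the scatter), and a 1.3-fold lower number from compound 1 to compound 4 (0.12 log units; within the scatter), so 3-bromophenyl reads the same as 4-phenylphenyl and 2-chlorophenyl at this position. No evidence at hand accounts for the gap.

From the compounds shown here alone, whether the lower number of compound 3 belongs to the five-membered ring or to its sulfur stays open. So does the outcome of an amine or a carboxylic acid on that thiophene.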